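Replacing an aryl urea by an alkyl urea with a methylpiperazine

The source may hold more compounds than are shown below. What is called first, only, known or untested is meant among the compounds shown, and "the series" means these compounds.

Three compounds share one core and differ only in the amine hanging from the benzylic carbon of the urea's aryl group. Compound 1 `CN1CCN(Cc2ccc(NC(=O)Nc3ccc4ncnc(Nc5cccc(C(F)(F)F)c5)c4c3)cc2)CC1` gives 1650 nM in a functional assay on A549 cells (Homo sapiens) for antiproliferative activity, read by MTT assay, with a stated time of 72 h; a higher number here means a weaker inhibitor, a lower number a stronger inhibitor; compound 2 `O=C(Nc1ccc(CN2CCCCC2)cc1)Nc1ccc2ncnc(Nc3cccc(C(F)(F)F)c3)c2c1` gives 1050 nM; compound 3 `CN(C)Cc1ccc(NC(=O)Nc2ccc3ncnc(Nc4cccc(C(F)(F)F)c4)c3c2)cc1` gives 1120 nM. The steps of a 1.6-fold lower number from compound 1 to compound 2 (0.20 log units; within the scatter), a 1.5-fold lower number from compound 1 to compound 3 (0.17 log units; within the scatter) and a 1.1-fold higher number from compound 2 to compound 3 (0.03 log units; within the scatter) are all within the scatter, so compound 3 stands among numbers that cannot be told apart, second highest only on paper.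

Compound 4 `CN1CCN(CCNC(=O)Nc2ccc3ncnc(Nc4cccc(C(F)(F)F)c4)c3c2)CC1` makes a different kind of change: 2-(4-methylpiperazin-1-yl)ethyl in place of 4-((dimethylamino)methyl)phenyl on an amide-type nitrogen. On these data alone, none of the three measured steps bear on this, since each only swapped one amine for another while the aromatic ring stayed; the gap between an aryl and an alkyl substituent on this nitrogen is untested here. For the measured compounds named here, with nothing measured to anchor it, compound 4 is expected to land near compound 3, a 1.8-fold higher number from compound 3 to compound 4 (0.25 log units; within the scatter), with a wide range because the only steps known, such as a 1.1-fold higher number from compound 2 to compound 3 (0.03 log units; within the scatter), concern a different part of the molecule. The estimate for compound 4 is 2000 nM, between 600 nM and 8000 nM.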

Compound 4, half-maximal inhibitory concentration: > 10000 nM
Compound 4 was reported as a limit; the forecaster's own chance of this, stated with the estimate: 5%; middle value at least 5.0-fold (0.69 log units) away from the limit.
By their numbers in this assay, from the lowest: compounds 2, 3 and 1 (each within the scatter of the next). At a limit, above all of these: compound 4.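

Among compounds 1, 2 and 3, exchanging one amine for another left the numbers within the scatter, but the group on the amide-type nitrogen proves far less forgiving: 2-(4-methylpiperazin-1-yl)ethyl in place of 4-((dimethylamino)methyl)phenyl gives an at least 8.9-fold higher number from compound 3 to compound 4 (0.95 log units; beyond the scatter). Compound 4 gives > 10000 nM in this assay, which is a limit of the assay and not a number. The step is therefore a minimum, and its full size stays unknown: the limit of > 10000 nM in this assay, at which 1 of the 4 values shown sits.

This single change removes the aromatic ring and alters the amine together, and the compounds shown cannot separate those two parts. On these data alone, it remains open whether a 2-(dimethylamino)ethyl group or a longer chain, such as 3-(4-methylpiperazin-1-yl)propyl, on this nitrogen would stay near compound 3 or fall at the same limit.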